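Inverting One Ring Stereocentre in a Closely Grouped Set

The source may report more compounds than this note shows. Statements on the series, on what has been measured and on what is new or still open speak of the compounds shown alone.

In a functional assay on MIA PaCa-2 cells (Homo sapiens) for inhibition, read by MTT assay, with a stated time of 3 days (on this read-out lower numbers stand for stronger inhibition and higher numbers for weaker inhibition), compound 2 `CCOC(=O)[C@@H]1C[C@@H](O)CN(S(=O)(=O)c2ccc(S(=O)(=O)N(CC)CC)cc2)C1` gives 2100 nM and lies within the scatter of the other two measured compounds. In this assay compound 1 `CCN(CC)S(=O)(=O)c1ccc(S(=O)(=O)N2CCC[C@@H](C(=O)NC3CN(C(=O)C4CC4)C3)C2)cc1` gives 3100 nM and compound 3 `CCN(CC)S(=O)(=O)c1ccc(S(=O)(=O)N2CCC[C@@H](C(=O)NC)C2)cc1` gives 2000 nM on the same read-out. Compound 4 `CCOC(=O)[C@@H]1C[C@H](O)CN(S(=O)(=O)c2ccc(S(=O)(=O)N(CC)CC)cc2)C1` differs from compound 2 in one way (the two compounds have the same atoms and bonds and differ only in configuration as drawn: 1 of 2 stereo elements differ; a stereocentre at a saturated ring carbon is drawn R in compound 2 and S in compound 4) and is otherwise identical. Within the data shown here, the only measured step (a 1.6-fold lower number from compound 1 to compound 3 (0.19 log units; within the scatter)) replaces a group on an amide-type nitrogen and tests no stereocentre, so the data offer no direct guide. The expected change (a 1.0-fold higher number from compound 2 to compound 4 (0.02 log units; within the scatter)) is therefore none beyond the scatter in this assay for now. Compound 4 is estimated at 2200 nM with an expected range from 1100 nM to 4400 nM in this read-out.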

Compound 4, half-maximal inhibitory concentration: 300 nM
Compound 4: middle estimate off by 7.3-fold (0.87 log units), on the high side, outside the stated range (below it).
By their numbers in this assay, from the lowest: compound 4; then compounds 3, 2 and 1 (each within the scatter of the next).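

In this assay, among these compounds, the configuration at this saturated ring carbon matters, which the earlier compounds, separated only by changes within the scatter, did not show. Inverting it from R to S gives a 7.0-fold lower number from compound 2 to compound 4 (0.85 log units; beyond the scatter) and no atom is added or lost. The gap can be laid to this one stereocentre alone because of what the pair shares: the fact that compounds 2 and 4 differ only in the configuration as drawn.

The compounds shown leave open whether drawing this carbon S keeps its lower number when a carboxylic acid replaces the ethyl ester or an amine replaces the hydroxyl. From the compounds shown here alone, the effect of inverting the second stereocentre also remains open.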